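The compounds below may be only part of what the source reports. "The series", "measured", "known", "first", "only" and "open" are said of these compounds alone.

Measured so far in a functional assay on BGC-823 cells (Homo sapiens) for antiproliferative activity, read by MTT assay, with a stated time of 48 h; on this read-out lower numbers stand for stronger inhibition and higher numbers for weaker inhibition:
Compound 1 `S=c1oc(-c2ccc3c(c2)OCCO3)nn1CN1CCN(c2cccc(Cl)c2Cl)CC1` gives 22600 nM.
Compound 2 `COc1cccc(N2CCN(Cn3nc(-c4ccc5c(c4)OCCO5)oc3=S)CC2)c1` gives > 50000 nM, which is a limit of this assay and not a number.

Within the data shown here, compound 1 therefore stands as the only compound of this pair with an actual number in this assay; the other value is a limit. Compound 3 `COc1ccc(N2CCN(Cn3nc(-c4ccc5c(c4)OCCO5)oc3=S)CC2)cc1` differs from compound 1 in one place: 4-methoxyphenyl in place of 2,3-dichlorophenyl on an amine nitrogen in a ring. Among the measured compounds shown here, one measured step bears on this change, the exchange of the same 2,3-dichlorophenyl for 3-methoxyphenyl, which gave an at least 2.2-fold higher number from compound 1 to compound 2 (0.34 log units; beyond the scatter); that step reached (the limit of > 50000 nM in this assay, at which 1 of the 2 values shown sits). Both changes put a methoxyphenyl in place of the 2,3-dichlorophenyl, so a step of at least modest size toward higher numbers is expected for compound 3, with a fair chance that the read-out is again a limit rather than a number. The step expected for compound 3 is a 2.2-fold higher number from compound 1 to compound 3 (0.34 log units; beyond the scatter). Compound 3 is estimated at 50000 nM, with a range from 20000 nM to 120000 nM.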

Compound 3, half-maximal inhibitory concentration: 18900 nM
The estimate for compound 3 lay 2.6-fold (0.42 log units) above the measured number, and the stated range ends above it.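

In this assay, the exchange of 2,3-dichlorophenyl for 4-methoxyphenyl gives a 1.2-fold lower number from compound 1 to compound 3 (0.08 log units; within the scatter), so a methoxyphenyl on this amine nitrogen is compatible with a read-out that matches that of the dichlorophenyl compound, and the loss seen with compound 2 does not extend to every methoxyphenyl group. What separates the two methoxyphenyl compounds is where the methoxy group sits on the phenyl ring: 4-methoxyphenyl in place of 3-methoxyphenyl gives an at least 2.6-fold lower number from compound 2 to compound 3 (0.42 log units; beyond the scatter). The size of that step cannot be fixed, as compound 2 gives a limit and not a number: the limit of > 50000 nM in this assay, at which 1 of the 3 values shown sits.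

The compounds shown leave open whether this dependence on the methoxy position is specific to methoxy or also appears with other groups on the phenyl ring, such as 3-chlorophenyl against 4-chlorophenyl, and how 2-methoxyphenyl or plain phenyl would read at this place. They also leave open whether any group on this amine nitrogen, a pyridyl ring or a benzyl group for instance, can bring the number clearly below the level shared by compound 1 and compound 3.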